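Aryl-to-alkyl swap at the sulfur-bound chain carbon

The compounds below may be only part of what the source reports. "The series", "measured", "known", "first", "only" and "open" are said of these compounds alone.

Compound 1 `Cc1cc(Nc2cc(-c3ccccc3)[nH]n2)n2nc(SCc3cccc(Br)c3)nc2n1`: 8900 nM
Compound 2 `Cc1cc(Nc2cc(-c3ccccc3)[nH]n2)n2nc(SCc3nc4ccccc4[nH]3)nc2n1`: 4840 nM
Compound 3 `Cc1cc(Nc2cc(-c3ccccc3)[nH]n2)n2nc(SCc3ccc(F)cc3)nc2n1`: 8110 nM

In a functional assay on PC-9 cells (Homo sapiens) for inhibition, read by MTT assay, with a stated time of 72 h (a lower number here means a stronger inhibitor, a higher number a weaker inhibitor), compound 1 gives 8900 nM, compound 2 gives 4840 nM and compound 3 gives 8110 nM. Among these three, compound 3 stands second highest; its nearest neighbour is compound 1, with a 1.1-fold lower number from compound 1 to compound 3 (0.04 log units; within the scatter), and its furthest is compound 2, with a 1.7-fold higher number from compound 2 to compound 3 (0.22 log units; within the scatter). The remaining pair, a 1.8-fold lower number from compound 1 to compound 2 (0.26 log units; within the scatter), is also within the scatter, so the three measured compounds cannot be told apart on these numbers.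

Compound 4 `CCCSc1nc2nc(C)cc(Nc3cc(-c4ccccc4)[nH]n3)n2n1` differs from compound 3 in one place: ethyl in place of 4-fluorophenyl on a saturated chain carbon bound to a sulfur. For the measured compounds named here, none of the measured steps touches this kind of change; all three swap one ring for another ring at the same chain carbon, and each stays within the scatter. The loss of the ring itself is therefore untested, and the measured steps give no direction beyond the scatter for it. Compound 4 is expected to give about 12000 nM, within 4000 nM to 40000 nM, an estimated step of a 1.5-fold higher number from compound 3 to compound 4 (0.17 log units; within the scatter).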

Compound 4, half-maximal inhibitory concentration: > 50000 nM
Compound 4: only a limit was reported; the forecaster's own chance of this, stated with the estimate: 20%; middle value at least 4.1-fold (0.61 log units) away from the limit.
By their numbers in this assay, from the lowest: compounds 2, 3 and 1 (each within the scatter of the next). At a limit, above all of these: compound 4.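

Compound 4 gives no number in this assay, only a limit of the assay: the limit of > 50000 nM in this assay, at which 1 of the 4 values shown sits. The ring-for-ring swaps on the saturated chain carbon bound to a sulfur all stayed within the scatter, but ethyl in place of a ring moves beyond it in every comparison, with an at least 6.1-fold higher number from compound 3 to compound 4 (0.78 log units; beyond the scatter), an at least 10-fold higher number from compound 2 to compound 4 (1.01 log units; beyond the scatter) and an at least 5.6-fold higher number from compound 1 to compound 4 (0.74 log units; beyond the scatter). For the compounds shown here, this position therefore shows no separation among the three rings, while the loss of the ring is the first change here to give a step beyond the scatter, and each such step is a lower bound set by the limit.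

The compounds shown leave open how far compound 4 lies past its limit. They also leave open whether an aromatic ring is needed at this carbon, or whether a cyclohexyl group, a longer chain or an amine would serve there.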